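Para substituent swaps on a shared pyrazoline-thiazole core

This account rests on a few compounds, and the source may have more. Where it says the series, first, only, none or still open, it means among the compounds named here.

Measured compounds:
- compound 1 `COc1ccc(-c2csc(N3N=C(c4ccc(C)cc4)CC3c3ccc4c(c3)OCCO4)n2)cc1`: 2680 nM
- compound 2 `COc1ccc(-c2csc(N3N=C(c4ccc(F)cc4)CC3c3ccc4c(c3)OCCO4)n2)cc1`: 4530 nM
- compound 3 `COc1ccc(C2=NN(c3nc(-c4ccc(OC)cc4)cs3)C(c3ccc4c(c3)OCCO4)C2)cc1`: 2730 nM

In a functional assay on MCF7 cells (Homo sapiens) for antiproliferative activity, read by MTT assay, with a stated time of 48 h (a lower number here means a stronger inhibitor, a higher number a weaker inhibitor), compound 3 gives 2730 nM, which places it second highest of the three numbers; its nearest neighbour is compound 1, with a 1.0-fold higher number from compound 1 to compound 3 (0.01 log units; within the scatter), and the furthest is compound 2, with a 1.7-fold lower number from compound 2 to compound 3 (0.22 log units; within the scatter). All three measured compounds share one core and differ only in the group on the same aromatic carbon.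

Compound 4 `COc1ccc(-c2csc(N3N=C(c4ccc(Br)cc4)CC3c3ccc4c(c3)OCCO4)n2)cc1` continues this series: bromo in place of methoxy on an aromatic carbon. Within the data shown here, the steps that bear on it are the three swaps at that carbon: a 1.7-fold higher number from compound 1 to compound 2 (0.23 log units; within the scatter), a 1.0-fold higher number from compound 1 to compound 3 (0.01 log units; within the scatter) and a 1.7-fold lower number from compound 2 to compound 3 (0.22 log units; within the scatter). None of them reached beyond the scatter, so a further swap at the same place is expected to leave this assay essentially unchanged, with no step beyond the scatter in either direction. For compound 4 the estimate is therefore 3200 nM, with a range of 1500 nM to 7000 nM, which means an expected step of a 1.2-fold higher number from compound 3 to compound 4 (0.07 log units; within the scatter).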

Compound 4, half-maximal inhibitory concentration: 870 nM
For compound 4 the middle estimate is 3.7-fold (0.57 log units) above the measured one; the whole stated range lies above it.
By their numbers in this assay, from the lowest: compound 4; then compounds 1, 3 and 2 (each within the scatter of the next).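

Among these compounds, until now every swap at this aromatic carbon had stayed within the scatter, but bromo is the first group there to shift the number beyond it in this assay, with a 3.1-fold lower number from compound 3 to compound 4 (0.50 log units; beyond the scatter), a 3.1-fold lower number from compound 1 to compound 4 (0.49 log units; beyond the scatter) and a 5.2-fold lower number from compound 2 to compound 4 (0.72 log units; beyond the scatter). The position is therefore not indifferent to its substituent, although methyl, fluoro and methoxy had made it look so. Compound 2 goes against any reading that extends this to halogens in general, since its fluoro does not share the lower number of compound 4, and nothing available here accounts for the gain.

As far as these compounds go, it remains open whether the lower number is particular to bromo or would also appear with chloro, iodo or trifluoromethyl at this carbon. From the compounds shown here alone, how an amine, a carboxylic acid or a longer chain such as butyl would behave there also remains unknown.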